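Methoxy to ethoxy on a trifluoromethyl-bearing bicyclic core

A few compounds are considered here, and "the series" means these few. Any claim that something is new, unique, unknown or untested is made for them only; others in the source may bear on it.

Compound 1, `Cc1ccc(-c2nn3c(=O)cc(C(F)(F)F)nc3s2)cc1C`, gives 540 nM in an assay on cells for inhibition of alkaline phosphatase, tissue-nonspecific isozyme (Homo sapiens), read by luminescence, with stated times of 7 min and 20 min; a lower number here means a stronger inhibitor, a higher number a weaker inhibitor. Compound 2, `COc1ccccc1-c1nn2c(=O)cc(C(F)(F)F)nc2s1`, gives 3480 nM. Compound 3, `COc1cc(OC)cc(-c2nn3c(=O)cc(C(F)(F)F)nc3s2)c1`, gives 1150 nM.

Among these three, compound 2 stands at the highest number and is therefore the weakest inhibitor of the set: compound 3 gives a lower number, and compound 1 a lower one still, both separations lying beyond the scatter of repeated measurement. Among the measured compounds shown here, no two of the measured compounds differ in a single place, so no single step between them is counted.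

Compound 4, `CCOc1ccccc1-c1nn2c(=O)cc(C(F)(F)F)nc2s1`, is not yet measured. It differs from compound 2 by methyl in place of hydrogen on a saturated chain carbon bound to an oxygen on an aromatic ring, which read one bond further out is methyl to ethyl, or methoxy to ethoxy. For the measured compounds named here, nothing among the measured compounds shows what such a lengthening does here. The step of a 1.2-fold lower number from compound 2 to compound 4 (0.06 log units; within the scatter) is expected to stay within the scatter. Compound 4 is therefore estimated to give 3000 nM, within a range from 1000 nM to 9000 nM.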

Compound 4, half-maximal inhibitory concentration: 4520 nM
The estimate for compound 4 lay 1.5-fold (0.18 log units) below the measured number, within the range that was stated.
By their numbers in this assay, from the lowest: compound 1; then compound 3; then compounds 2 and 4 (each within the scatter of the next).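

Methoxy to ethoxy is the first single change that can be read in this set: in this assay it amounts to a 1.3-fold higher number from compound 2 to compound 4 (0.11 log units; within the scatter), so compound 2 and compound 4 cannot be told apart. At this position, then, methyl in place of hydrogen on a saturated chain carbon bound to an oxygen on an aromatic ring leaves no difference that repeated measurement could separate. Nothing available gives a reason for this result.

The compounds shown leave open whether a longer chain such as propoxy, a branched isopropoxy, or a hydroxyl or an amine in place of the ether would separate from compound 2. They also leave open whether the same lengthening would read alike on the methoxy groups of compound 3.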